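This account rests on a few compounds, and the source may have more. Where it says the series, first, only, none or still open, it means among the compounds named here.

Compound 1 `Cc1nc(S(C)(=O)=O)ccc1Oc1ncnc(OC2CCN(C(=O)OC3CCC3)CC2)c1F` gives 81% in a functional assay on isolated protein for inhibition of Glucose-dependent insulinotropic receptor (Rattus norvegicus), read by HTRF and cAMP accumulation; on this read-out lower numbers stand for smaller maximal responses and higher numbers for larger maximal responses.
Compound 2 `Cc1nc(S(C)(=O)=O)ccc1Oc1ncnc(OC2CCN(C(=O)OC(C)F)CC2)c1F` gives 68%.
Compound 3 `Cc1nc(S(C)(=O)=O)ccc1Oc1ncnc(OC2CCN(C(=O)O[C@@H](C)CF)CC2)c1F` gives 84%.

Compound 3 carries the highest of the three numbers, but its margin over compound 1 is small: the step of a number 3 percentage points higher from compound 1 to compound 3 (within the scatter) lies within the scatter, while the step of a number 16 percentage points higher from compound 2 to compound 3 (beyond the scatter) lies beyond it. All three compounds share one core and differ only in the group on the oxygen next to the carbonyl group.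

Compound 4 `Cc1nc(S(C)(=O)=O)ccc1Oc1ncnc(OC2CCN(C(=O)OC3COC3)CC2)c1F` is not yet measured. It differs from compound 3 as follows: oxetan-3-yl in place of 1-(fluoromethyl)ethyl on an oxygen next to a carbonyl group

Going by the values given here, the steps that bear on this change are the three that swap the group on that same oxygen. The step of a number 13 percentage points lower from compound 1 to compound 2 (beyond the scatter) and the step of a number 16 percentage points higher from compound 2 to compound 3 (beyond the scatter) were both modest, and the step of a number 3 percentage points higher from compound 1 to compound 3 (within the scatter) was within the scatter. Compound 1, which carries cyclobutyl at that oxygen, gives a number within the scatter of compound 3, so a swap to oxetan-3-yl is expected to move the maximal response little, if at all, with a slight downward lean because of a number 3 percentage points higher from compound 1 to compound 3 (within the scatter) being small. Compound 4 is therefore estimated to give about 79%, expected between 67% and 91%. The expected step of a number 5 percentage points lower from compound 3 to compound 4 (within the scatter) thus lies within the scatter.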

Compound 4, largest response reached (reported as efficacy), in percent of the reference or control that the assay uses: 66%
Estimate against measurement, compound 4: 13 percentage points above; the measured number lies below the stated range.
By their numbers in this assay, from the lowest: compounds 4 and 2 (each within the scatter of the next); then compounds 1 and 3 (each within the scatter of the next).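

In this assay, a ring on this oxygen does not by itself hold the maximal response: the change from cyclobutyl to oxetan-3-yl gives a number 15 percentage points lower from compound 1 to compound 4 (beyond the scatter) and so separates two ring-bearing groups, although no earlier compound had shown such a separation between rings. The change from the open-chain 1-(fluoromethyl)ethyl to oxetan-3-yl likewise gives a number 18 percentage points lower from compound 3 to compound 4 (beyond the scatter) and is a real loss, whereas the change from 1-fluoroethyl to oxetan-3-yl gives a number 2 percentage points lower from compound 2 to compound 4 (within the scatter) and leaves the two groups indistinguishable, so the four groups now fall into a lower pair, oxetan-3-yl with 1-fluoroethyl, and a higher pair, cyclobutyl with 1-(fluoromethyl)ethyl. The data offer no measured property that accounts for this division of the four groups, and no explanation for it can be given here.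

Still open, as far as these compounds go, is how an azetidine ring, with nitrogen where oxetan-3-yl has its oxygen, or a longer ether chain would behave on this oxygen. The mirror-image form of 1-(fluoromethyl)ethyl is also open, as is whether the division among these groups would persist on a core other than the shared one.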